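The compounds below may be only part of what the source reports. "The series", "measured", "known", "first", "only" and "open" are said of these compounds alone.

Three ureas share one core. In a functional assay on HT-29 cells (Homo sapiens) for cytotoxicity, read by MTT assay, with a stated time of 72 h (a lower number here means a stronger inhibitor, a higher number a weaker inhibitor), compound 1 `O=C(Nc1ccc(-n2ncc3c(C(F)(F)F)cccc32)cc1)Nc1ccc(Cl)c(C(F)(F)F)c1` gives 2900 nM and compound 2 `O=C(Nc1ccc(-n2ncc3c(F)cccc32)cc1)Nc1ccc(Cl)c(C(F)(F)F)c1` gives 8200 nM; compound 2 thus holds the higher of the two numbers, the step of a 2.8-fold higher number from compound 1 to compound 2 (0.45 log units; beyond the scatter) lying beyond the scatter. Compound 3 `COc1cccc2c1cnn2-c1ccc(NC(=O)Nc2ccc(Cl)c(C(F)(F)F)c2)cc1` reaches only the limit > 32000 nM in this assay. The steps of an at least 11-fold higher number from compound 1 to compound 3 (1.04 log units; beyond the scatter) and an at least 3.9-fold higher number from compound 2 to compound 3 (0.59 log units; beyond the scatter) are larger still. Compound 4 `O=C(Nc1ccc(-n2ncc3ccncc32)cc1)Nc1ccc(Cl)c(C(F)(F)F)c1` carries a group of 9 heavy atoms (6 carbon, 3 nitrogen; one five-membered aromatic ring with 2 hetero atoms, one six-membered aromatic ring with 1 hetero atom) in place of a group of 10 heavy atoms (7 carbon, 2 nitrogen, 1 fluorine; one five-membered aromatic ring with 2 hetero atoms, one six-membered aromatic ring of carbon only), on an aromatic carbon. Each measured change at that ring has raised the number, so for compound 4 a modest further rise is expected, giving a 1.8-fold higher number from compound 2 to compound 4 (0.26 log units; within the scatter) in this assay. Compound 4 is therefore estimated at 15000 nM in this assay, within a range from 5000 nM to 40000 nM.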

Compound 4, half-maximal inhibitory concentration: 29500 nM
Beside the measured number, compound 4's estimate is 2.0-fold (0.29 log units) below it; low and high end bracket the measured number.
By their numbers in this assay, from the lowest: compound 1; then compound 2; then compound 4. At a limit, above all of these: compound 3.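

Among these compounds, the change gives a 3.6-fold higher number from compound 2 to compound 4 (0.56 log units; beyond the scatter) in this assay, so altering the six-membered aromatic ring itself, with a ring nitrogen and no fluoro, also raises the number, whereas the earlier steps only exchanged a group on a ring of carbon only. Compound 3 remains a limit and the only one in the set: the limit of > 32000 nM in this assay, at which 1 of the 4 values shown sits.

The compounds shown cannot separate the loss of fluoro from the entry of the ring nitrogen, since both fall within this one step. They also leave open whether an amine or a carboxylic acid on this ring would lower the number.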